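The source may report more compounds than this note shows. Statements on the series, on what has been measured and on what is new or still open speak of the compounds shown alone.

In a functional assay on K562 cells (Homo sapiens) for cytotoxicity, read by fluorescence, with a stated time of 72 h (on this read-out higher numbers stand for weaker inhibition and lower numbers for stronger inhibition), the measured compounds read:

- Compound 1 `CC(C)c1n[nH]c2c(NCc3ccc(-c4ccccn4)cc3)nc(NCCN)nc12`: 63 nM
- Compound 2 `CC(C)c1n[nH]c2c(NCc3ccc(-c4ccccn4)cc3)nc(N[C@@H]3CCCC[C@H]3N)nc12`: 175 nM
- Compound 3 `CC(C)c1n[nH]c2c(NCc3ccc(-c4ccccn4)cc3)nc(NCC(N)CO)nc12`: 700 nM

Compound 3, at 700 nM, has the highest number of the three, which makes it the weakest of the set. Compound 4 `COc1ccc(CNc2nc(NCc3ccc(-c4ccccn4)cc3)c3[nH]nc(C(C)C)c3n2)cc1` has not yet been measured. Its difference from compound 3 is 4-methoxyphenyl in place of 1-amino-2-hydroxyethyl on a saturated chain carbon bound to a nitrogen on an aromatic ring. Cut one bond further out, 4-methoxybenzyl replaces 2-amino-3-hydroxypropyl.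

The measured steps that bear on this change all concern the same chain. Among them, a 2.8-fold higher number from compound 1 to compound 2 (0.44 log units; beyond the scatter) is modest, a 4.0-fold higher number from compound 2 to compound 3 (0.60 log units; beyond the scatter) is also modest, and an 11-fold higher number from compound 1 to compound 3 (1.05 log units; beyond the scatter) is large. These steps show that changes at this place can move the number considerably. However, all three measured chains carry an amino group, and none carries an aromatic ring, so no measured compound matches the new group directly. In this assay, a modest step towards a higher number is therefore expected, though with wide uncertainty, and a larger step would not be surprising. The expected change is a 2.1-fold higher number from compound 3 to compound 4 (0.33 log units; beyond the scatter). For compound 4, the estimated value is 1500 nM, with an expected range from 350 nM to 6000 nM.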

Compound 4, half-maximal inhibitory concentration: 3950 nM
Compound 4: middle estimate off by 2.6-fold (0.42 log units), on the low side, within the range that was stated.
By their numbers in this assay, from the lowest: compound 1; then compound 2; then compound 3; then compound 4.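

In this assay, the 4-methoxybenzyl chain, the only one shown that carries an aromatic ring and no amino group, gives the highest number of the series: the change brings a 5.6-fold higher number from compound 3 to compound 4 (0.75 log units; beyond the scatter) and, measured against the other two chains, a 23-fold higher number from compound 2 to compound 4 (1.35 log units; beyond the scatter) and a 63-fold higher number from compound 1 to compound 4 (1.80 log units; beyond the scatter) in turn. All three chains bearing an amino group therefore give lower numbers than this one, and the spread at this position reaches further than those chains showed on their own, yet the change removes the amino group and the hydroxyl and brings in the ring all at once, so the rise cannot be assigned to any one of these. Nothing available here accounts for the rise.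

From the compounds shown here alone, it remains open whether losing the amino group or gaining the ring matters more, a question that a 4-aminobenzyl chain or a plain 2-hydroxyethyl chain at this place would separate. The part played by the methoxy group also stays unsettled, and an unsubstituted benzyl chain or a 4-carboxybenzyl chain would speak to it.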